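Trimethoxyphenyl series against gastric carcinoma cells: working notes

The compounds below may be only part of what the source reports. "The series", "measured", "known", "first", "only" and "open" are said of these compounds alone.

Measured so far:
compound 1 `COc1ccc(/C=N/NC(=O)c2cc(OC)c(OC)c(OC)c2)c(OC)c1`: 3.6%
compound 2 `COc1cc(C2=NN(C(C)=O)C(c3c(Cl)cccc3Cl)O2)cc(OC)c1OC`: 15.9%

Two compounds have numbers in a functional assay on BGC-823 cells (Homo sapiens) for antiproliferative activity, read by MTT assay, tested at 5 uM; on this read-out lower numbers stand for a weaker effect and higher numbers for a stronger effect at the one concentration tested. Compound 2 stands highest of the two; the nearest is compound 1, whose number is lower by a margin beyond the usual scatter. Among the measured compounds shown here, no pair among the measured compounds differs in a single place, so no single change has a measured step attached to it.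

Compound 3 `COc1ccc(OC)c(C2OC(c3cc(OC)c(OC)c(OC)c3)=NN2C(C)=O)c1` is still to be measured in this assay. Against compound 2 the change is 2,5-dimethoxyphenyl in place of 2,6-dichlorophenyl on a saturated ring carbon. Nothing measured here isolates such a replacement on the saturated ring carbon, so the step is expected to be small: a number 3.9 percentage points lower from compound 2 to compound 3 (within the scatter), with no direction that should be trusted beyond the scatter. The number for compound 3 is estimated at 12%, expected to fall between 2% and 28%.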

Compound 3, a percentage reported as inhibition, at one concentration (the size of the read-out at that concentration, not a potency): 18.2%
Compound 3: middle estimate off by 6.2 percentage points, on the low side, within the range that was stated.
By their numbers in this assay, from the lowest: compound 1; then compounds 2 and 3 (each within the scatter of the next).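

In this assay, among the compounds shown here, the replacement of 2,6-dichlorophenyl by 2,5-dimethoxyphenyl on the saturated ring carbon gives a number 2.3 percentage points higher from compound 2 to compound 3 (within the scatter) and is the first measured step at this position. Two quite different substituted phenyl groups, one carrying two chlorine atoms and the other two methoxy groups with two hydrogen-bond acceptors, therefore cannot be told apart on this read-out at the one concentration tested. No supporting measurement bears on this result, so the step stands without an assigned cause.

Open, as far as these compounds go, is whether an amine or a carboxylic acid on this phenyl ring, or a longer alkyl chain in place of the ring, would move the read-out beyond the scatter. Also open, from the compounds shown here alone, is what replacing the acetyl group with a propanoyl group would do on the shared core.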